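Turning the enone arm around in compound 2

The compounds below may be only part of what the source reports. "The series", "measured", "known", "first", "only" and "open" are said of these compounds alone.

Measured so far, in a functional assay on A549 cells (Homo sapiens) for antiproliferative activity, read by MTT assay, with a stated time of 24 h; on this read-out lower numbers stand for stronger inhibition and higher numbers for weaker inhibition:
- compound 1, `COc1cc(C(=O)/C=C/c2cc(-c3cc(OC)c(OC)c(OC)c3)n3nc(-c4ccccc4)cc3n2)cc(OC)c1OC`: 20500 nM
- compound 2, `COc1ccc(/C=C/C(=O)c2cc(-c3ccc(OC)c(OC)c3)n3nc(-c4ccccc4)cc3n2)cc1`: 19300 nM
- compound 3, `COc1cc(-c2cc(C(=O)/C=C/c3ccccc3)nc3cc(-c4ccccc4)nn23)cc(OC)c1OC`: 18000 nM

All three numbers lie close together, and the gaps from compound 2 to compound 1 and from compound 2 to compound 3 are both within the scatter, so no ranking of the three can be read from these data; each is a weak inhibitor in this assay.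

Compound 4, `COc1ccc(C(=O)/C=C/c2cc(-c3ccc(OC)c(OC)c3)n3nc(-c4ccccc4)cc3n2)cc1`, is an isomer of compound 2 built from the same atoms joined differently: 2-((4-methoxyphenyl)carbonyl)ethenyl in place of (2-(4-methoxyphenyl)ethenyl)carbonyl on an aromatic carbon. The carbonyl and the alkene simply swap ends, so the whole enone arm is turned around while the shared core and the 3,4-dimethoxyphenyl group stay put.

For the measured compounds named here, no measured pair shows what such a reversal does, so the expectation rests only on the shared weak range of compounds 1 to 3. Compound 4 is estimated at 20000 nM, with a range from 8000 nM to 50000 nM. The expected step is a 1.0-fold higher number from compound 2 to compound 4 (0.02 log units; within the scatter), which is no change beyond the scatter.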

Compound 4, half-maximal inhibitory concentration: 11900 nM
The estimate for compound 4 lay 1.7-fold (0.23 log units) above the measured number; the range from low to high includes it.
By their numbers in this assay, from the lowest: compounds 4, 3, 2 and 1 (each within the scatter of the next).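

For the compounds shown here, this is the first pair here that differs in only one place. In this assay, turning the enone arm around on this aromatic carbon, with 2-((4-methoxyphenyl)carbonyl)ethenyl in place of (2-(4-methoxyphenyl)ethenyl)carbonyl, gives a 1.6-fold lower number from compound 2 to compound 4 (0.21 log units; within the scatter). At this position, then, swapping the ends of the carbonyl and the alkene makes no difference that can be told apart from the scatter of repeated measurements, and nothing available explains why the two isomers read alike.

Still open, as far as these compounds go, is whether the arm's direction would matter with another end group, such as an amine or a carboxylic acid in place of the 4-methoxyphenyl ring. The effect of a saturated chain in place of the alkene at this position is also unknown.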